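The source may hold more compounds than are shown below. What is called first, only, known or untested is meant among the compounds shown, and "the series" means these compounds.

Measured compounds:
Compound 1 `C[C@@H](NC(=O)Nc1ccc(C(C)(C)C)cc1)c1ccccc1`: 53%
Compound 2 `CCOC(=O)c1ccc(NC(=O)N[C@H](C)c2ccccc2)cc1`: 92%

In an ADME assay on the whole organism with Oryza sativa as the target, tested at 10 uM (on this read-out higher numbers stand for a weaker effect at the one concentration tested and lower numbers for a stronger effect), compound 2 gives the highest of the two numbers shown; its nearest neighbour is compound 1, and the step between them is a number 39 percentage points higher from compound 1 to compound 2 (beyond the scatter). Compound 3 `CC(=O)c1ccc(NC(=O)N[C@H](C)c2ccccc2)cc1` has not yet been measured in this assay. It differs from compound 2 in one place: methyl in place of ethoxy on a carbonyl carbon.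

Within the data shown here, only one measured step exists, a number 39 percentage points higher from compound 1 to compound 2 (beyond the scatter), and it came from putting ethoxycarbonyl in place of tert-butyl on an aromatic carbon, a large step upward. Among the measured compounds shown here, the change from compound 2 to compound 3 is a different one, cutting the ethoxy down to methyl on the carbonyl carbon, and no measured pair shows this change directly. The bearing of the measured step is therefore indirect, and the expected movement is modest: compound 3 is estimated to stand a little below compound 2, with a step of a number 8 percentage points lower from compound 2 to compound 3 (within the scatter) that may not exceed the scatter. On that basis compound 3 is expected to give 84% in this assay, within a range from 64% to 98%.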

Compound 3, a percentage reported as activity, at one concentration (the size of the read-out at that concentration, not a potency): 84%
Compound 3: the middle estimate sits on the measured number at the digits printed; the range from low to high includes it.
By their numbers in this assay, from the lowest: compound 1; then compounds 3 and 2 (each within the scatter of the next).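

In this assay, methyl in place of ethoxy on a carbonyl carbon gives a number 8 percentage points lower from compound 2 to compound 3 (within the scatter) so this read-out does not tell ethoxycarbonyl and acetyl apart at this place, and the ethoxy part of the group is not needed for a high number. Acetyl in place of tert-butyl on an aromatic carbon gives a number 31 percentage points higher from compound 1 to compound 3 (beyond the scatter) so the large upward step first seen with ethoxycarbonyl is seen again with a second group that carries a carbonyl, and neither of the two compounds goes against this. No measurement shown here explains why these groups stand so far from tert-butyl.

The compounds shown do not tell whether the high numbers go with the carbonyl itself or simply with the loss of tert-butyl, and a carboxylic acid, a primary amide or a lone methyl on the same aromatic carbon would bear on that question. On these data alone, it also remains open how far the carbonyl carbon accepts other groups, such as a longer chain like butoxy or an amine.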